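The source may report more compounds than this note shows. Statements on the series, on what has been measured and on what is new or still open speak of the compounds shown alone.

Within the data shown here, compound 2 `CC(=O)OC/C(=C\c1ccc(Cl)cc1)C(=O)c1ccccc1` gives 2600 nM in a functional assay on SW1573 cells (Homo sapiens) for inhibition, read by sulforhodamine B assay, with a stated time of 48 h (a lower number here means a stronger inhibitor of growth, a higher number a weaker inhibitor of growth), the lowest of the two numbers recorded; its nearest neighbour is compound 1 `O=C(/C(=C/c1ccc(Cl)cc1)CCl)c1ccccc1`, which gives 3900 nM, and the only step measured so far, a 1.5-fold lower number from compound 1 to compound 2 (0.18 log units; within the scatter), lies within the scatter. Compound 3 `CC(=O)OC/C(=C\c1ccccc1F)C(=O)c1ccccc1` differs from compound 2 by 2-fluorophenyl in place of 4-chlorophenyl on a double-bonded chain carbon bound to a double-bonded chain carbon. Among the measured compounds shown here, no measured step touches this aryl group, since the one step known concerns the chain substituent, so compound 3 is expected to show no step beyond the scatter, a 1.2-fold higher number from compound 2 to compound 3 (0.06 log units; within the scatter). Compound 3 is therefore estimated at 3000 nM, between 1000 nM and 9000 nM.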

Compound 3, concentration for 50% growth inhibition: 6100 nM
The estimate for compound 3 lay 2.0-fold (0.31 log units) below the measured number; the range from low to high includes it.
By their numbers in this assay, from the lowest: compounds 2, 1 and 3 (each within the scatter of the next, the first and the last beyond it).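

In this assay, the aryl group on a double-bonded chain carbon bound to a double-bonded chain carbon proves to be a place where a change registers: 2-fluorophenyl in place of 4-chlorophenyl gives a 2.3-fold higher number from compound 2 to compound 3 (0.37 log units; beyond the scatter) and this modest step lies beyond the scatter. Among these compounds, the only earlier step, at the chain substituent, stayed within it. Nothing available explains this step. The swap alters both the halogen and its ring position, and the compounds shown do not separate the two. They also leave open how an unsubstituted phenyl or an aryl group carrying an amine would read here.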